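The source may hold more compounds than are shown below. What is called first, only, known or untested is meant among the compounds shown, and "the series" means these compounds.

Measured so far:
Compound 1, `Clc1ccc(C2CC(c3ccccc3)=NN2c2ccc(-c3ccccc3)nn2)cc1`: 100000 nM
Compound 2, `COc1ccc(C2CC(c3ccccc3)=NN2c2ccc(-c3ccccc3)nn2)cc1`: 91700 nM
Compound 3, `Clc1ccc(C2=NN(c3ccc(-c4ccccc4)nn3)C(c3ccccc3)C2)cc1`: 96700 nM

Of the compounds shown here, three have been tested in a functional assay on A549 cells (Homo sapiens) for antiproliferative activity, read by MTT assay, with a stated time of 24 h; on this read-out higher numbers stand for weaker inhibition and lower numbers for stronger inhibition. Compound 1 has the structure `Clc1ccc(C2CC(c3ccccc3)=NN2c2ccc(-c3ccccc3)nn2)cc1`, and in this assay compound 1 gives 100000 nM. Compound 2, `COc1ccc(C2CC(c3ccccc3)=NN2c2ccc(-c3ccccc3)nn2)cc1`, carries methoxy in place of chloro on an aromatic carbon; in this assay compound 2 gives 91700 nM, a step of a 1.1-fold lower number from compound 1 to compound 2 (0.04 log units; within the scatter). Compound 3, `Clc1ccc(C2=NN(c3ccc(-c4ccccc4)nn3)C(c3ccccc3)C2)cc1`, is built from the same atoms as compound 1 joined differently; the difference between the two cores is not broken down here. In this assay compound 3 gives 96700 nM, a value lying within the scatter of those of compound 1 and compound 2. All three numbers sit at the weak end of the read-out, and no ordering among them can be claimed.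

Compound 4, `COc1ccc(C2=NN(c3ccc(-c4ccccc4)nn3)C(c3ccccc3)C2)cc1`, has not yet been measured. It differs from compound 3 by methoxy in place of chloro on an aromatic carbon, the same change that separates compound 2 from compound 1, and this change occurs twice among the compounds shown. For the measured compounds named here, in the one measured instance the step was a 1.1-fold lower number from compound 1 to compound 2 (0.04 log units; within the scatter). For compound 4 the expected step in this assay is a 1.1-fold lower number from compound 3 to compound 4 (0.04 log units; within the scatter), which rests on that single earlier example, because a 1.1-fold lower number from compound 1 to compound 2 (0.04 log units; within the scatter) stayed within the scatter. In this assay compound 4 is therefore estimated at 88000 nM, with a likely range from 55000 nM to 140000 nM.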

Compound 4, half-maximal inhibitory concentration: 75900 nM
For compound 4 the middle estimate is 1.2-fold (0.06 log units) above the measured one; measured number inside the range.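

In this assay, 4-methoxyphenyl in place of 4-chlorophenyl gives a 1.3-fold lower number from compound 3 to compound 4 (0.11 log units; within the scatter), and set beside the earlier instance of the same change, the two steps do not differ: the same change on two cores in this assay, a 1.1-fold lower number (0.04 log units; within the scatter) from compound 1 to compound 2 and a 1.3-fold lower number (0.11 log units; within the scatter) from compound 3 to compound 4, 1.2-fold (0.07 log units) apart, within the scatter of two such steps. Within this pair of cores, then, the step seen on the core of compound 1 carries over to the core of compound 3 in the limited sense that neither step can be told from the other, and nothing here suggests that the choice of core alters what this change does. It does not show that the change itself has any effect on either core, as both steps lie within the scatter, and agreement between two steps this small, with all four numbers at the weak end of the read-out, says little about whether a larger step would carry over in the same way.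

The compounds shown leave open whether another group in the same place, such as an amine, a carboxylic acid or a longer chain, would move the number beyond the scatter. They also leave open whether such a step would then be the same on the core of compound 1 and the core of compound 3, which would be a firmer test of carrying a change between them.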